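The source may report more compounds than this note shows. Statements on the series, on what has been measured and on what is new or still open speak of the compounds shown alone.

Compound 1 `C=C[C@@](C)(/C=C/c1ccc(OS(=O)(=O)C(F)(F)F)cc1)CCC=C(C)C` was tested in a functional assay on HepG2 cells (Homo sapiens) for cytotoxicity, with a stated time of 72 h; on this read-out higher numbers stand for an effect only at larger amounts of compound and lower numbers for an effect already at smaller amounts. In this assay compound 1 gives only a limit, > 52000 nM. Compound 2 `C=C[C@@](C)(/C=C/c1ccc(OS(=O)(=O)c2ccc(C)cc2)cc1)CCC=C(C)C` carries 4-methylphenyl in place of trifluoromethyl on a sulfonyl sulfur. In this assay compound 2 likewise gives only a limit, > 52000 nM. Compound 3 `COc1ccc(/C=C/[C@@](C)(/C=C/c2ccc(O)cc2)CCC=C(C)C)cc1` also returns only a limit in this assay, > 52000 nM. Among the measured compounds shown here, the single step from compound 1 to compound 2 is a step that the two limits leave unreadable from compound 1 to compound 2, so it tells nothing about direction or size. Compound 1 thus stands at the limit of > 52000 nM in this assay, at which 3 of the 3 values shown sit, and no measured number anywhere in the set separates one compound from another.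

Compound 4 `C=C[C@@](C)(/C=C/c1ccc(-c2ccc(Cl)cc2)cc1)CCC=C(C)C` has yet to be measured. It differs from compound 1 in that (4-chlorophenyl in place of ((trifluoromethyl)sulfonyl)oxy on an aromatic carbon), the new group sitting on an aromatic carbon of a six-membered aromatic ring of carbon only, para to a large group. For the measured compounds named here, no measured step bears on this change: the only step known is unreadable, and all three values are limits. No step beyond the scatter can therefore be predicted, in either direction. On this basis the expected value of compound 4 in this assay is 60000 nM, within 15000 nM to 200000 nM. The step from compound 1 to compound 4 is expected to be a step that the limit leaves unreadable from compound 1 to compound 4, and it is thought likely that compound 4 too will be reported only as a limit.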

Compound 4, half-maximal effective concentration: > 52000 nM
Compound 4 ended at the assay's limit; the forecaster's own chance of this, stated with the estimate: 60%; the middle value lies beyond the limit too.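

In this assay compound 4 also gives only a limit, > 52000 nM. No step from compound 1 to compound 4 can therefore be read, and all the compounds remain at the same limit: the limit of > 52000 nM in this assay, at which 4 of the 4 values shown sit.

The compounds shown leave open whether any of them differs from another in this assay, and which change to the shared core, if any, would yield a measured number.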